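This account rests on a few compounds, and the source may have more. Where it says the series, first, only, none or still open, it means among the compounds named here.

Measured so far:
- compound 1, `COc1cc2c(cc1OC)C(CC(=O)Nc1cccc(Cl)c1)CC2`, gives 31.3%
- compound 2, `COc1cc2c(cc1OC)C(CC(=O)Nc1ccc(Br)cc1)CC2`, gives 50%

Both numbers come from a functional assay on the whole organism (strain Wistar) for inhibition, with Rattus norvegicus as the target, read by paw edema, with a stated time of 1 h, at a dose of 100 mg/kg; a higher number here means more inhibition at the dose given (going by the name of the read-out), a lower number less inhibition. Among the two values known, compound 2 stands highest: the only step measured, a number 18.7 percentage points higher from compound 1 to compound 2 (beyond the scatter), shows compound 1 lying lower by an amount beyond the usual scatter, so the order of these two is trustworthy.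

The next compound, compound 3, `COc1cc2c(cc1OC)C(CC(=O)Nc1ccncc1)CC2`, differs from compound 2 in one place: pyridin-4-yl in place of 4-bromophenyl on an amide-type nitrogen. Among the measured compounds shown here, the one measured step exchanged one halogen-bearing phenyl for another; it did not exchange a phenyl for a ring carrying a nitrogen, so it only loosely bears on the present change. What it does show is that the amide-bound ring alone can move the read-out by a modest amount, as a number 18.7 percentage points higher from compound 1 to compound 2 (beyond the scatter) did. For the measured compounds named here, with no closer precedent, the expectation for compound 3 is a modest fall from compound 2, namely a number 15 percentage points lower from compound 2 to compound 3 (beyond the scatter), with the range left wide. Compound 3 is thus estimated at 35%, expected to fall between 15% and 58%.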

Compound 3, a percentage reported as inhibition, in the whole organism at one dose (the size of the read-out at that dose, not a potency): 42.2%
Compound 3: the middle estimate sits 7.2 percentage points below what was measured; the range from low to high includes it.
By their numbers in this assay, from the lowest: compound 1; then compounds 3 and 2 (each within the scatter of the next).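

In this assay, putting pyridin-4-yl in place of 4-bromophenyl on the amide-type nitrogen gives a small difference (a number 7.8 percentage points lower from compound 2 to compound 3 (within the scatter)), so this read-out does not separate these two groups. Compound 3 carries no halogen, which shows that, among these three compounds, a halogen on the amide-bound ring is not required to reach a number of this size. The comparison with the 3-chlorophenyl group reads differently (a number 10.9 percentage points higher from compound 1 to compound 3 (beyond the scatter)), so a ring with a nitrogen in it stands clear of compound 1, and the halogen-bearing rings do not all sit on the same side of compound 3. Nothing available explains these numbers.

The compounds shown leave open how a plain phenyl ring with no substituent, or pyridin-3-yl with its ring nitrogen elsewhere, would compare with these three groups on the amide-type nitrogen. They also leave open whether a saturated ring such as piperidine, or a carboxylic acid or an amine on the amide-bound ring, would keep a read-out of this size, and whether the order seen at this single dose would hold at others.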